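Fluoro for methoxy on the sulfonyl-bearing phenyl

The source may report more compounds than this note shows. Statements on the series, on what has been measured and on what is new or still open speak of the compounds shown alone.

Measured compounds:
compound 1 `COc1ccc(S(=O)(=O)c2nc3ccccc3nc2Nc2cc(OC)cc(OC)c2)cc1`, 12700 nM
compound 2 `COc1ccc(S(=O)(=O)c2nc3ccccc3nc2Nc2cc(OC)c(OC)c(OC)c2)cc1`, 5170 nM
compound 3 `Nc1ccc(Nc2nc3ccccc3nc2S(=O)(=O)c2ccc(Br)cc2)cc1`, 1020 nM

In a functional assay on A549 cells (Homo sapiens) for cytotoxicity, read by MTT assay, with a stated time of 72 h (a higher number here means a weaker inhibitor, a lower number a stronger inhibitor), compound 2 stands second highest of the three numbers. Going by the values given here, the one measured step is a 2.5-fold lower number from compound 1 to compound 2 (0.39 log units; beyond the scatter), and compound 3, with 1020 nM, gives the lowest number but differs from compound 2 in more than one place. Compound 4 `COc1cc(Nc2nc3ccccc3nc2S(=O)(=O)c2ccc(F)cc2)cc(OC)c1OC` differs from compound 2 by fluoro in place of methoxy on an aromatic carbon. Among the compounds with values here, no measured step alters only that group, so the direction is open; the account expects a step of a 1.3-fold lower number from compound 2 to compound 4 (0.11 log units; within the scatter), not clearly beyond the scatter. Compound 4 is therefore estimated at 4000 nM, within 1500 nM to 11000 nM.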

Compound 4, half-maximal inhibitory concentration: > 50000 nM
Compound 4 was reported as a limit; the forecaster's own chance of this, stated with the estimate: 3%; middle value at least 12-fold (1.09 log units) from the limit.
By their numbers in this assay, from the lowest: compound 3; then compound 2; then compound 1. At a limit, above all of these: compound 4.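

Going by these compounds alone, at this position, 4-methoxyphenyl to 4-fluorophenyl gives an at least 9.6-fold higher number from compound 2 to compound 4 (0.98 log units; beyond the scatter) in this assay, so the group on this aromatic carbon matters far more than the earlier compounds could show. Within the data shown here, the only earlier single change, a 2.5-fold lower number from compound 1 to compound 2 (0.39 log units; beyond the scatter), lay elsewhere on the molecule and was much smaller. The result for compound 4 is a limit and not a number, so the step gives only a minimum size: the limit of > 50000 nM in this assay, at which 1 of the 4 values shown sits.

From the compounds shown here alone, how far the true step extends stays open. Whether an amine, a hydroxyl or a chlorine at this position would retain the activity of the methoxy group also remains unanswered.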